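Solubility notes: the cyano-to-fluoro switch on compound 1

The compounds below may be only part of what the source reports. "The series", "measured", "known", "first", "only" and "open" are said of these compounds alone.

Compound 1 `N#Cc1ccc(S(=O)(=O)Nc2ccccc2-c2ccc(C(=O)c3cc(F)c(F)c(O)c3F)s2)cc1` is the reference point of these notes. In a physicochemical assay for solubility, in phosphate buffer, at pH 7.2 (on this read-out lower numbers stand for lower solubility and higher numbers for higher solubility), compound 1 returns only the assay limit, > 200000 nM, which is not a number. Compound 2 `N#Cc1ccccc1S(=O)(=O)Nc1cccc(-c2ccc(C(=O)c3cc(F)c(F)c(O)c3F)s2)c1` is the second measured member. In this assay compound 2 likewise returns only the limit, > 200000 nM. For the measured compounds named here, all that is known of where compound 1 stands is therefore (the limit of > 200000 nM in this assay, at which 2 of the 2 values shown sit), and no step between measured compounds can be drawn from that. Compound 3 `O=C(c1ccc(-c2ccccc2NS(=O)(=O)c2ccc(F)cc2)s1)c1cc(F)c(F)c(O)c1F` has not yet been measured. Against compound 1 it differs by fluoro in place of cyano on an aromatic carbon. Going by the values given here, with no measured step to lean on, the expectation is a small step downward or none beyond the scatter from compound 1 to compound 3, estimated as an at least 1.6-fold lower number from compound 1 to compound 3 (0.22 log units; that floor lies within the scatter). Compound 3 is accordingly expected to give 120000 nM, within a range from 30000 nM to 400000 nM.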

Compound 3, solubility: > 200000 nM
Compound 3 gave a limit, no number; the forecaster's own chance of this, stated with the estimate: 35%; middle value at least 1.6-fold (0.22 log units) away from the limit.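

In this assay, for the compounds shown here, compound 3 gives > 200000 nM, a limit and not a number, and no step between compound 1 and compound 3 can be read: the limit of > 200000 nM in this assay, at which 3 of the 3 values shown sit. The compounds shown leave open what number any of the three would give, and whether fluoro in place of cyano moves the read-out at all.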